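The compounds below may be only part of what the source reports. "The series", "measured", "known", "first", "only" and "open" are said of these compounds alone.

Working notes on the series

Two compounds of this set have a number in a physicochemical assay for lipophilicity, read by HPLC, with a stated time of 90 min, tested at 100 uM (on this read-out lower numbers stand for lower lipophilicity and higher numbers for higher lipophilicity), so far. Compound 1 `O=C(Nc1ccc(OC(F)(F)F)cc1)NC1CCN(C(=O)c2ccoc2)CC1` carries a furan-3-yl on the carbonyl carbon of the ring amide, and in this assay compound 1 gives 3.63. Compound 2 `CC(C)C(=O)N1CCC(NC(=O)Nc2ccc(C(F)(F)F)c(F)c2)CC1` is the other measured member, and in this assay compound 2 gives 4.4. Of these two numbers compound 1 stands lowest; compound 2 lies higher, a gap beyond the scatter. For the measured compounds named here, no pair differing in one place has been measured, so no single step is yet established.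

Compound 3 `O=C(Nc1ccc(OC(F)(F)F)cc1)NC1CCN(C(=O)C2CCCOC2)CC1` is the next member and differs from compound 1 in one place: oxan-3-yl in place of furan-3-yl on a carbonyl carbon. The leaving group is a five-membered aromatic ring with one hetero atom; the entering group is a six-membered non-aromatic ring with one hetero atom, one heavy atom larger, with the same count of donors and acceptors. The step in this assay from compound 1 to compound 3 is expected to be small and downward, close to the edge of the scatter, estimated at a number 0.28 log units lower from compound 1 to compound 3 (within the scatter). For compound 3 the expected value in this assay is 3.35, within a range of 2.9 to 3.8.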

Compound 3, partition coefficient: 3.42
The estimate for compound 3 lay 0.07 log units below the measured number, within the range that was stated.
By their numbers in this assay, from the lowest: compounds 3 and 1 (each within the scatter of the next); then compound 2.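

Compound 3 gives the series its first single-place step: on a carbonyl carbon whose other neighbour is an amide-type nitrogen in a ring, oxan-3-yl in place of furan-3-yl gives, in this assay, a number 0.21 log units lower from compound 1 to compound 3 (within the scatter). At this position, then, a six-membered non-aromatic ring with 1 hetero atom and 6 heavy atoms can stand in place of a five-membered aromatic ring with 1 hetero atom and 5 heavy atoms, with the same count of hydrogen-bond donors and acceptors, and the read-out cannot be told apart from that of compound 1. No measured information is at hand to explain this result.

Both rings carry 1 oxygen as their hetero atom, so the compounds shown leave open whether a ring amine, a carboxylic acid or a longer open alkyl chain on this carbonyl would give a step beyond the scatter in this assay. As far as these compounds go, compound 2 differs from compound 1 and compound 3 in more than one place, so whether this change would read the same on the core of compound 2 also remains open.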